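Swapping the trifluoromethyl for chloro on the urea aryl ring

A few compounds are considered here, and "the series" means these few. Any claim that something is new, unique, unknown or untested is made for them only; others in the source may bear on it.

Measured so far:
compound 1, `COc1cc2cc(Oc3ccc(NC(=O)Nc4cccc(C(F)(F)F)c4)cc3)c(C)nc2cc1OC`, 16300 nM
compound 2, `COc1cc2cc(Oc3ccc(NC(=O)Nc4ccc(Cl)c(C(F)(F)F)c4)cc3)c(C)nc2cc1OC`, 6120 nM

In a functional assay on SN12C cells (Homo sapiens) for inhibition, read by sulforhodamine B assay, with a stated time of 48 h (on this read-out lower numbers stand for stronger inhibition of growth and higher numbers for weaker inhibition of growth), compound 2 gives 6120 nM, the lowest of the two numbers; its nearest neighbour is compound 1 with 16300 nM. For the measured compounds named here, the one measured step, a 2.7-fold lower number from compound 1 to compound 2 (0.43 log units; beyond the scatter), was a modest change, beyond the scatter. Compound 3, `COc1cc2cc(Oc3ccc(NC(=O)Nc4ccc(Cl)c(Cl)c4)cc3)c(C)nc2cc1OC`, has not been measured. It differs from compound 2 by chloro in place of trifluoromethyl on an aromatic carbon, on an aromatic carbon ortho to a chloro group and meta to a large group. Going by the values given here, no measured step bears on this exchange: the step from compound 1 to compound 2 concerns the chloro that both compound 2 and compound 3 keep. Compound 3 is therefore expected to sit close to compound 2 in this assay, with a step of a 1.5-fold higher number from compound 2 to compound 3 (0.17 log units; within the scatter), perhaps towards a somewhat higher number but not clearly beyond the scatter. The estimate for compound 3 is 9000 nM, within 3000 nM to 27000 nM.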

Compound 3, concentration for total growth inhibition: 20500 nM
Beside the measured number, compound 3's estimate is 2.3-fold (0.36 log units) below it, within the range that was stated.
By their numbers in this assay, from the lowest: compound 2; then compounds 1 and 3 (each within the scatter of the next).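

In this assay, the exchange of trifluoromethyl for chloro on this aromatic carbon, ortho to a chloro group, gives a 3.3-fold higher number from compound 2 to compound 3 (0.53 log units; beyond the scatter), so at this place the two groups are not interchangeable when the second chloro is present. Set against the compound without that second chloro, the result reads a 1.3-fold higher number from compound 1 to compound 3 (0.10 log units; within the scatter), so the 3,4-dichlorophenyl and 3-(trifluoromethyl)phenyl compounds cannot be told apart, and the advantage of compound 2 is seen only where chloro and trifluoromethyl occur together. Nothing given here explains why the trifluoromethyl counts at this place.

The compounds shown leave open whether only trifluoromethyl keeps the lower number of compound 2, or whether a bromo, a nitrile or a methyl at this place would do the same. They also leave open how a methoxy or an amine would behave here.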